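The compounds below may be only part of what the source reports. "The series", "measured", "known", "first", "only" and "open" are said of these compounds alone.

Within the data shown here, in an ADME assay for permeability, read by LC-MS, using PAMPA, with a stated time of 3 h (a higher number here means that the compound crosses the layer faster, a lower number that the compound crosses the layer more slowly), compound 1 (`Cn1cc(-c2ccc(N(C(=O)NCc3ccccc3)[C@H]3CC[C@H](Nc4ccc(C#N)cn4)CC3)cc2)cn1`) gives 288 nm/s and is the only compound here with a number. Compound 2 (`Cn1cccc(-c2ccc(N(C(=O)NCc3ccccc3)[C@H]3CC[C@H](Nc4ccc(C#N)cn4)CC3)cc2)c1=O`) has the entry "not determined" (no result reported) and compound 3 (`Cn1c(-c2ccc(N(C(=O)NCc3ccccc3)[C@H]3CC[C@H](Nc4ccc(C#N)cn4)CC3)cc2)cccc1=O`) has the entry "not determined" (no result reported) so compound 3 offers no figure for comparison. Compound 4 (`Cn1ccc(-c2ccc(N(C(=O)NCc3ccccc3)[C@H]3CC[C@H](Nc4ccc(C#N)cn4)CC3)cc2)cc1=O`) has the same atoms as compound 3, joined differently. One ring group replaces another of the same makeup on an aromatic carbon of a six-membered aromatic ring of carbon only, para to a large group (a group of 8 heavy atoms (6 carbon, 1 nitrogen, 1 oxygen; one six-membered aromatic ring with 1 hetero atom) in place of a group of 8 heavy atoms (6 carbon, 1 nitrogen, 1 oxygen; one six-membered aromatic ring with 1 hetero atom), on an aromatic carbon). Among the measured compounds shown here, no measured step is available, and no step beyond the scatter is expected in this assay on going from compound 3. The value of compound 1 at 288 nm/s is the sole anchor, so the range must stay wide. For compound 4 the expected value is 160 nm/s (estimated range 50 nm/s to 400 nm/s).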

Compound 4, apparent permeability: 247 nm/s
Compound 4: the middle estimate sits 1.5-fold (0.19 log units) below what was measured; measured number inside the range.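

In this assay, a six-membered aromatic ring group of 8 heavy atoms in place of a five-membered aromatic ring group gives a 1.2-fold lower number from compound 1 to compound 4 (0.07 log units; within the scatter) and so shows that, on this aromatic carbon para to a large group, the exchange stays within the usual scatter. Nothing measured here offers an explanation for this result.

Steps involving compound 2 and compound 3 cannot be read, so the effect of how the ring is joined remains open. On these data alone, it is also open whether an amine or a carboxylic acid at this position would leave the number within the scatter.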